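The source may hold more compounds than are shown below. What is called first, only, known or untested is meant among the compounds shown, and "the series" means these compounds.

Measured so far in an ADME assay on MDCK cells (Canis lupus familiaris) for permeability, read by LC-MS, with a stated time of 90 min, tested at 2 uM; a lower number here means that the compound crosses the layer more slowly, a higher number that the compound crosses the layer faster:

- compound 1 `COC(c1cc(Cl)c2c(c1Cl)C(=O)N(Cc1c(C)cc(C)[nH]c1=O)CC2)C1CCOC1`: 17.1 10^-6 cm/s; 18.7 10^-6 cm/s; 15.4 10^-6 cm/s; 18.4 10^-6 cm/s (4 entries)
- compound 2 `Cc1cc(C)c(CN2CCc3c(Cl)cc([C@H](CO)[C@H]4CCCO4)c(Cl)c3C2=O)c(=O)[nH]1`: 4.1 10^-6 cm/s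
- compound 3 `Cc1cc(C)c(CN2CCc3c(Cl)cc(C(CO)C4CCOC4)c(Cl)c3C2=O)c(=O)[nH]1`: 2.5 10^-6 cm/s; 2.7 10^-6 cm/s (2 entries)

Compound 2 at 4.1 10^-6 cm/s sits well under compound 1 and within the scatter of compound 3. The repeat entries hold together for compound 1 the several entries of compound 1 in this assay, 17.1 10^-6 cm/s; 18.7 10^-6 cm/s; 15.4 10^-6 cm/s; 18.4 10^-6 cm/s (4 entries) and for compound 3 the several entries of compound 3 in this assay, 2.5 10^-6 cm/s; 2.7 10^-6 cm/s (2 entries) in these notes.

Compound 4 `Cc1cc(C)c(CN2CCc3c(Cl)cc([C@@H](CO)[C@H]4CCCO4)c(Cl)c3C2=O)c(=O)[nH]1` has yet to be measured. Against compound 2 the change is the two compounds have the same atoms and bonds and differ only in configuration as drawn: 1 of 2 stereo elements differ; a stereocentre at a saturated chain carbon is drawn R in compound 2 and S in compound 4 and a stereocentre at a saturated chain carbon is drawn R in compound 2 and S in compound 4.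

Within the data shown here, no measured pair isolates such a change. The expectation therefore rests on the nearest values, compound 2 at 4.1 10^-6 cm/s and compound 3 at 2.5 10^-6 cm/s; 2.7 10^-6 cm/s (2 entries), which lie within the scatter of each other. In this assay no step beyond the scatter is expected, and neither direction is favoured. The expected move is a 1.0-fold lower number from compound 2 to compound 4 (0.01 log units; within the scatter) and it stays inside the scatter. For compound 4 the estimated value is 4 10^-6 cm/s with a range of 2 10^-6 cm/s to 8 10^-6 cm/s for now.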

Compound 4, apparent permeability: 8.5 10^-6 cm/s
Compound 4: the middle estimate sits 2.1-fold (0.33 log units) below what was measured; measured number outside the range, above it.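

Among these compounds, the only measured step that isolates configuration lies beyond the scatter in this assay, with a 2.1-fold higher number from compound 2 to compound 4 (0.32 log units; beyond the scatter), so the stereocentre at a saturated chain carbon that differs here is not silent in this read-out: the fact that compounds 2 and 4 differ only in the configuration as drawn. Among the compounds shown here, earlier values offered no such comparison, since no two measured compounds differed in one place. The step is modest and rests on a single pair, so it sets no rule for the rest of the series.

The compounds shown do not tell whether the stereocentre that stays the same as drawn would give a step of similar size if inverted. They also leave open whether the change in configuration would matter as much with an amine or a carboxylic acid in place of the hydroxyl.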